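Carbamate to sulfonamide on the piperidine nitrogen

A few compounds are considered here, and "the series" means these few. Any claim that something is new, unique, unknown or untested is made for them only; others in the source may bear on it.

In a functional assay on CHO-K1 cells for agonist activity at Glucose-dependent insulinotropic receptor (Homo sapiens), read by a luciferase reporter, with a stated time of 5 h (a lower number here means that less compound is needed, a higher number that more compound is needed for the effect), compound 1 `CC(C)(C)OC(=O)N1CCC(Oc2ncnc3c2CCN3c2ccc(S(C)(=O)=O)cc2F)CC1` gives 20 nM. Compound 2 `CCOC(=O)N1CCC(Oc2ncnc3c2CCN3c2ccc(S(C)(=O)=O)cc2F)CC1` gives 251 nM in this assay, and compound 3 `COCCOC(=O)N1CCC(Oc2ncnc3c2CCN3c2ccc(S(C)(=O)=O)cc2F)CC1` gives 316 nM. Compound 3 thus carries the highest of the three numbers; it is separated from compound 2 only within the scatter, as a 1.3-fold higher number from compound 2 to compound 3 (0.10 log units; within the scatter) shows, whereas the gap to compound 1 is large, a 16-fold higher number from compound 1 to compound 3 (1.20 log units; beyond the scatter). The parallel step a 13-fold higher number from compound 1 to compound 2 (1.10 log units; beyond the scatter) points the same way: the branched tert-butyl group stands apart from both straight chains.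

Compound 4 `CC(C)S(=O)(=O)N1CCC(Oc2ncnc3c2CCN3c2ccc(S(C)(=O)=O)cc2F)CC1` is the next step: isopropylsulfonyl in place of (2-methoxyethoxy)carbonyl on an amine nitrogen in a ring. Within the data shown here, no measured pair covers a change of the carbonyl-bearing group for a sulfonyl, so the measured steps bear only indirectly. On these data alone, they show that the shape of the group on this nitrogen matters, with a branched group giving the lowest number, but whether that carries over to a sulfonyl group is unknown. A moderate decrease in this assay is expected, with wide uncertainty, and compound 4 is estimated at 100 nM (range 20 nM to 500 nM); the expected step is a 3.2-fold lower number from compound 3 to compound 4 (0.50 log units; beyond the scatter).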

Compound 4, half-maximal effective concentration: 1260 nM
The estimate for compound 4 lay 13-fold (1.10 log units) below the measured number, and the stated range ends below it.
By their numbers in this assay, from the lowest: compound 1; then compounds 2 and 3 (each within the scatter of the next); then compound 4.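

In this assay, isopropylsulfonyl on an amine nitrogen in a ring is the only group shown at this position without a carbonyl, and it gives a higher number than all three carbonyl-bearing groups, beyond the scatter in each case: a 4.0-fold higher number from compound 3 to compound 4 (0.60 log units; beyond the scatter), a 5.0-fold higher number from compound 2 to compound 4 (0.70 log units; beyond the scatter) and a 63-fold higher number from compound 1 to compound 4 (1.80 log units; beyond the scatter). A branched group here therefore does not by itself give a low number: among the groups with a carbonyl, branched tert-butoxycarbonyl gives the lowest number, but compound 4, with its branched isopropyl, goes against any wider pattern. Nothing available explains the higher number of compound 4.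

The compounds shown do not separate the effect of the sulfonyl from that of the isopropyl, which a tert-butylsulfonyl or ethylsulfonyl group on the same nitrogen would address. On these data alone, it also remains open how a urea or an amide carrying a tert-butyl group would compare with compound 1.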